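Acetamidophenyl replaces dibromophenyl on the sulfonyl sulfur

A few compounds are considered here, and "the series" means these few. Any claim that something is new, unique, unknown or untested is made for them only; others in the source may bear on it.

Compound 1 `COc1cc(N)c(Cl)cc1C(=O)CCC1CCN(CCNS(=O)(=O)c2cc(Br)ccc2Br)CC1` gives 16% in an assay on HEK293 cells for displacement of a labelled ligand from 5-hydroxytryptamine receptor 6 (Homo sapiens), with a stated time of 60 min, tested at 0.01 uM, in the presence of a further agent that is not named here (a lower number here means a weaker effect, a higher number a stronger effect of the compound at the concentration tested), the highest of the two numbers at hand. Compound 3 `COc1ccc(S(=O)(=O)NCCN2CCC(CCC(=O)c3cc(Cl)c(N)cc3OC)CC2)cc1OC` gives 3%, and compound 2 `COc1cc(N)c(Cl)cc1C(=O)CCC1CCN(CCNS(=O)(=O)c2ccc(C)cc2)CC1` is reported as "not active" (no number reported). Within the data shown here, the one measured step, a number 13 percentage points lower from compound 1 to compound 3 (beyond the scatter), shows that exchanging the aryl group on the sulfonyl sulfur lowers the read-out beyond the scatter. Compound 4 `COc1cc(N)c(Cl)cc1C(=O)CCC1CCN(CCNS(=O)(=O)c2ccc(NC(C)=O)cc2)CC1` differs from compound 1 by 4-acetamidophenyl in place of 2,5-dibromophenyl on a sulfonyl sulfur. This change bears on the same place as the step to compound 3, and the only other aryl variant, compound 2, showed nothing. Compound 4 is therefore expected to give a lower number, the step estimated as a number 11 percentage points lower from compound 1 to compound 4 (beyond the scatter). In this assay compound 4 is estimated at 5%, with a range from -5% to 15%.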

Compound 4, a percentage reported as inhibition, at one concentration (the size of the read-out at that concentration, not a potency): 7%
Estimate against measurement, compound 4: 2 percentage points below; the measured number falls inside the stated range.
By their numbers in this assay, from the lowest: compounds 3, 4 and 1 (each within the scatter of the next, the first and the last beyond it).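

With 4-acetamidophenyl on the sulfonyl sulfur, the measured steps are a number 9 percentage points lower from compound 1 to compound 4 (within the scatter) and a number 4 percentage points higher from compound 3 to compound 4 (within the scatter) in this assay. Compound 4 therefore cannot be told apart from either compound, although the earlier pair stands apart by a number 13 percentage points lower from compound 1 to compound 3 (beyond the scatter). This change thus gives no clear separation from either aryl group already measured at this position. No evidence is available to explain this result. The compounds shown leave open whether an amine or a carboxylic acid in place of the acetamido group would give a read-out beyond the scatter from compound 1.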